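A few compounds are considered here, and "the series" means these few. Any claim that something is new, unique, unknown or untested is made for them only; others in the source may bear on it.

Working notes on the series. Compound 1 `CC(C)c1ccc(Nc2ccc3c(OCCCN4CCN(C)CC4)cccc3n2)cc1` gives 12900 nM in a functional assay on PC-3 cells (Homo sapiens) for inhibition, read by sulforhodamine B assay, with a stated time of 48 h (a higher number here means a weaker inhibitor of growth, a lower number a stronger inhibitor of growth), the highest of the two numbers in hand. Within the data shown here, compound 2 `CN1CCN(CCCOc2cccc3nc(Nc4ccc(F)c(F)c4)ccc23)CC1` gives 3830 nM in this assay; the only measured step, a 3.4-fold lower number from compound 1 to compound 2 (0.53 log units; beyond the scatter), shows that a smaller halogenated aryl group on that nitrogen goes with a lower number, beyond the scatter.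

Compound 3 `CN1CCN(CCCOc2cccc3nc(Nc4cccc(Cl)c4)ccc23)CC1` is not yet measured. It differs from compound 1 by 3-chlorophenyl in place of 4-isopropylphenyl on a nitrogen on an aromatic ring. The step from compound 1 to compound 2 is the only one that bears on this change, and it is of the same kind: the 4-isopropylphenyl group replaced by a smaller aryl group carrying halogen. A lowering of similar, perhaps somewhat smaller, size is therefore expected for compound 3, which is the expected step of a 2.3-fold lower number from compound 1 to compound 3 (0.37 log units; beyond the scatter). The estimated value of compound 3 in this assay is 5500 nM, with a range of 2000 nM to 15000 nM.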

Compound 3, concentration for 50% growth inhibition: 1810 nM
Estimate against measurement, compound 3: 3.0-fold (0.48 log units) above; measured number outside the range, below it.
By their numbers in this assay, from the lowest: compound 3; then compound 2; then compound 1.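

In this assay the lowering on leaving 4-isopropylphenyl at this nitrogen is not confined to compound 2, since 3-chlorophenyl also gives one (a 7.1-fold lower number from compound 1 to compound 3 (0.85 log units; beyond the scatter)). The two halogenated aryl groups are also not equivalent, as the direct comparison between them gives (a 2.1-fold lower number from compound 2 to compound 3 (0.33 log units; beyond the scatter)), which places 3-chlorophenyl lowest of the three groups at this position. Nothing available gives a reason for this order.

Compound 2 and compound 3 differ in both the halogen and the pattern of substitution on the aryl ring, so the contribution of each cannot be separated. On these data alone, it remains open whether 4-chlorophenyl, 3-bromophenyl or unsubstituted phenyl would extend this order, and whether it would hold with a longer chain in place of the propyl chain on the oxygen.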